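The compounds below may be only part of what the source reports. "The series", "measured", "known", "first", "only" and "open" are said of these compounds alone.

The measured compounds and their values in an assay on CHO-K1 cells for antagonist activity at transient receptor potential cation channel subfamily V member 1 (Homo sapiens), read by FLIPR and calcium flux, with a stated time of 6 min; on this read-out lower numbers stand for stronger inhibition and higher numbers for weaker inhibition:
compound 1, `Cn1ncc2c(NC(=O)NCc3cc(C(F)(F)F)nn3-c3cccc(Cl)c3)cccc21`, gives 2.3 nM
compound 2, `Cn1ncc2c(NC(=O)NCc3cc(C(C)(C)C)nn3-c3cccc(Cl)c3)cccc21`, gives 0.4 nM
compound 3, `CC(=O)n1ncc2c(NC(=O)NCc3cc(C(C)(C)C)nn3-c3cccc(Cl)c3)cccc21`, gives 29.5 nM

Among these three, compound 2 gives the lowest number: a 5.8-fold lower number from compound 1 to compound 2 (0.76 log units; beyond the scatter), and a 74-fold higher number from compound 2 to compound 3 (1.87 log units; beyond the scatter). Compound 4, `Cn1ncc2c(NC(=O)NCc3cc(C(C)(C)C)nn3-c3ccc(C(F)(F)F)cc3)cccc21`, is not yet measured. It differs from compound 2 in one place: 4-(trifluoromethyl)phenyl in place of 3-chlorophenyl on an aromatic nitrogen. Neither measured step touches this part of the molecule: one exchanges tert-butyl for trifluoromethyl on an aromatic carbon, the other exchanges acetyl for methyl on an aromatic nitrogen. Among the compounds with values here, no measured step therefore speaks directly to the exchange of one phenyl group for another, and the data give no guide to its direction. In that situation the most reasonable expectation is a number close to that of compound 2, with room for a shift either way. The estimate for compound 4 in this assay is 1 nM, expected to lie between 0.2 nM and 5 nM. The expected step, a 2.5-fold higher number from compound 2 to compound 4 (0.40 log units; beyond the scatter), is small and may fall within the scatter.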

Compound 4, inhibition constant: 12.4 nM
Beside the measured number, compound 4's estimate is 12-fold (1.09 log units) below it; the measured number lies above the stated range.
By their numbers in this assay, from the lowest: compound 2; then compound 1; then compound 4; then compound 3.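

The aryl group on the aromatic nitrogen of the five-membered ring clearly matters: in this assay, 4-(trifluoromethyl)phenyl in place of 3-chlorophenyl gives a 31-fold higher number from compound 2 to compound 4 (1.49 log units; beyond the scatter) and so this position does not treat all substituted phenyl groups alike. Both groups are a single six-membered aromatic ring of carbon with no hydrogen-bond donors or acceptors, so this large step comes without any change in those counts. Nothing shown here explains the weaker inhibition of this exchange.

The exchange alters both the substituent, chlorine to trifluoromethyl, and its place on the phenyl ring, and these two changes cannot be told apart here. 4-Chlorophenyl or 3-(trifluoromethyl)phenyl on the same nitrogen would separate them, and plain phenyl would show what either substituent contributes at all.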